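The compounds below may be only part of what the source reports. "The series", "measured", "known", "first", "only" and "open" are said of these compounds alone.

Of the compounds shown here, three that share one core have been measured in a functional assay on HEK293 cells for agonist activity at G-protein coupled receptor 39 (Homo sapiens), read by scintillation proximity assay and inositol phosphate accumulation, with a stated time of 75 min, in the presence of a further agent that is not named here; a lower number here means that less compound is needed, a higher number that more compound is needed for the effect. Compound 1 `Cc1nn(-c2ncnc3nc[nH]c23)c2c1C(OC1CCCC1)CC(=O)N2` carries a cyclopentyl on an oxygen on a saturated carbon, and in this assay compound 1 gives 2 nM. Compound 2 `Cc1cc(C)n(CCOC2CC(=O)Nc3c2c(C)nn3-c2ncnc3nc[nH]c23)n1` carries a 2-(3,5-dimethyl-1H-pyrazol-1-yl)ethyl at that oxygen, and compound 2 gives 16 nM. Compound 3 `Cc1nn(-c2ncnc3nc[nH]c23)c2c1C(OC(=O)c1ccc(F)cc1)CC(=O)N2` carries a (4-fluorophenyl)carbonyl there, and compound 3 gives 4 nM. Compound 3 therefore stands second of the three numbers: its gap to compound 1, a 2.0-fold higher number from compound 1 to compound 3 (0.30 log units; within the scatter), lies within the scatter, whereas a 4.0-fold lower number from compound 2 to compound 3 (0.60 log units; beyond the scatter) lies beyond it.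

Compound 4 `COc1ccc(CCOC2CC(=O)Nc3c2c(C)nn3-c2ncnc3nc[nH]c23)cc1` has not yet been measured. Its change from compound 3 is 2-(4-methoxyphenyl)ethyl in place of (4-fluorophenyl)carbonyl on an oxygen on a saturated carbon. The step that bears most on this is an 8.0-fold higher number from compound 1 to compound 2 (0.90 log units; beyond the scatter), in which an ethyl-linked aromatic ring on that oxygen went with a higher number; the same pattern appears in a 4.0-fold lower number from compound 2 to compound 3 (0.60 log units; beyond the scatter) read in reverse. Compound 4 also carries an ethyl-linked aromatic ring at that oxygen, so a higher number than compound 3 is expected, though the phenyl here differs from the pyrazole of compound 2, leaving the size uncertain. The expected step is a 2.0-fold higher number from compound 3 to compound 4 (0.30 log units; within the scatter). For compound 4 the estimated value is 8 nM, with a range from 3 nM to 25 nM.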

Compound 4, half-maximal effective concentration: 2 nM
The estimate for compound 4 lay 4.0-fold (0.60 log units) above the measured number, outside the stated range (below it).
By their numbers in this assay, from the lowest: compounds 1, 4 and 3 (each within the scatter of the next); then compound 2.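

For the compounds shown here, an ethyl chain on the oxygen does not by itself go with a higher number, as the earlier compounds suggested: with the chain kept, 4-methoxyphenyl in place of 3,5-dimethyl-1H-pyrazol-1-yl on the saturated chain carbon gives a clear step (an 8.0-fold lower number from compound 2 to compound 4 (0.90 log units; beyond the scatter)). In this assay, the oxygen on a saturated carbon therefore accepts 2-(4-methoxyphenyl)ethyl as well as cyclopentyl (no change at the digits printed from compound 1 to compound 4 (within the scatter)) and (4-fluorophenyl)carbonyl (a 2.0-fold lower number from compound 3 to compound 4 (0.30 log units; within the scatter)), with neither step rising above the scatter, and among these four compounds only compound 2 stands apart. Nothing on hand explains why the group at the end of the chain matters here.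

The compounds shown do not separate the part played by the pyrazole ring from that of its two methyl groups, which a plain pyrazol-1-yl at the end of the same ethyl chain would address. They also leave open how far this tolerance extends, for instance to a dimethylamino group or a carboxylic acid at the chain end, or to a propyl chain carrying the same 4-methoxyphenyl.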